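The source may report more compounds than this note shows. Statements on the series, on what has been measured and on what is new or still open speak of the compounds shown alone.

Notes on the pyrazoline series in an assay on isolated protein for inhibition of protein kinase C zeta type (Homo sapiens), with a stated time of 4 min, tested at 62.5 uM; on this read-out higher numbers stand for more inhibition at the one concentration tested (going by the name of the read-out) and lower numbers for less inhibition. Of the compounds shown here, three have numbers so far. Compound 1 `CC(C)(C)C1=NN(c2ccc(C(=O)O)cc2)C(c2ccc(O)cc2)C1` gives 47.9%. Compound 2 `CC(C)(C)C1=NN(c2ccc(Cl)cc2Cl)C(c2ccc(O)cc2)C1` gives 71%. Compound 3 `CC(C)(C)C1=NN(c2ccc(Cl)cc2)C(c2ccc(F)cc2)C1` gives 0%, the lowest of the three, separated from compound 1 and from compound 2 by gaps beyond the scatter. Within the data shown here, no single-point steps between measured compounds are available, so nothing yet isolates one change.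

Compound 4 `CC(C)(C)C1=NN(c2ccc(Cl)cc2)C(c2ccc(O)c(Cl)c2)C1` differs from compound 3 in one place: 3-chloro-4-hydroxyphenyl in place of 4-fluorophenyl on a saturated ring carbon. The two measured compounds that carry a hydroxyphenyl group at this ring carbon, compound 1 and compound 2, both sit well above compound 3, so the step from compound 3 to compound 4 is expected to be an increase beyond the scatter, about a number 45 percentage points higher from compound 3 to compound 4 (beyond the scatter). Compound 4 is estimated at 45%, within 10% to 75%.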

Compound 4, a percentage reported as inhibition, at one concentration (the size of the read-out at that concentration, not a potency): 94.5%
For compound 4 the middle estimate is 49.5 percentage points below the measured one, and the stated range ends below it.
By their numbers in this assay, from the lowest: compound 3; then compound 1; then compound 2; then compound 4.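

In this assay, among these compounds, the saturated ring carbon next to the ring nitrogen is a highly sensitive position: with the rest of the structure unchanged, 3-chloro-4-hydroxyphenyl in place of 4-fluorophenyl gives a number 94.5 percentage points higher from compound 3 to compound 4 (beyond the scatter) in the first single-place comparison of the series. No measurement shown explains the size of this step.

The change replaces fluorine with both a chlorine and a hydroxy group, so the compounds shown do not separate the contribution of each. Also open, as far as these compounds go, is whether a methoxy group or an amine in place of the hydroxy group would retain the inhibition.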